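Swapping a methyl ether for an amine-bearing ester

The compounds below may be only part of what the source reports. "The series", "measured", "known", "first", "only" and "open" are said of these compounds alone.

Compound 1 `CCOC(=O)c1c(C)coc1-c1ccc2c(CC)cccc2c1OC` gives 2.2 ug/mL in a functional assay on KB cells (Homo sapiens) for cytotoxicity, read by MTT assay, with a stated time of 72 h; a higher number here means that more compound is needed for the effect, a lower number that less compound is needed. Compound 2 `CCc1cccc2c(OC)c(-c3occ(C)c3COC)ccc12` carries a methoxymethyl in place of the ethoxycarbonyl on the same aromatic carbon. In this assay compound 2 gives > 10 ug/mL, which is a limit of the assay and not a number. That change produced an at least 4.5-fold higher number from compound 1 to compound 2 (0.65 log units; beyond the scatter). Compound 2 therefore stands at the limit of > 10 ug/mL in this assay, at which 1 of the 2 values shown sits, the weaker end of the two values shown. Compound 3 `CCc1cccc2c(OC)c(-c3occ(C)c3COC(=O)CCN(CC)CC)ccc12` has not yet been measured; it differs from compound 2 by (2-(diethylamino)ethyl)carbonyl in place of methyl on an oxygen on a saturated carbon, so the methyl ether becomes an ester carrying a carbonyl. Within the data shown here, the one measured step, from a carbonyl-bearing group to the methyl ether, lost activity; restoring a carbonyl might win part of that back, but since compound 2 starts at a limit the size of an at least 1.2-fold lower number from compound 2 to compound 3 (0.09 log units; that floor lies within the scatter) is uncertain and is expected to be modest. Compound 3 is estimated at 8 ug/mL, between 2 ug/mL and 30 ug/mL.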

Compound 3, concentration for half-maximal effect: > 10 ug/mL
Compound 3: a limit, no number; the forecaster's own chance of this, stated with the estimate: 45%; middle value at least 1.2-fold (0.09 log units) from the limit.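

In this assay compound 3 gives > 10 ug/mL, a limit and not a number, so no step can be read from compound 2, which also stands at a limit: the limit of > 10 ug/mL in this assay, at which 2 of the 3 values shown sit.

Left open is whether the (2-(diethylamino)ethyl)carbonyl of compound 3 changes activity at all compared with the methyl of compound 2, and how far either compound lies past that limit.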